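Acetylthiourea series: trifluoromethyl added to the bromophenyl compound

The source may hold more compounds than are shown below. What is called first, only, known or untested is meant among the compounds shown, and "the series" means these compounds.

Working notes on a small set of acetylthioureas tested in an assay for inhibition of epoxide hydrolase 1 (Homo sapiens), read by fluorescence, using microsomes; a higher number here means a weaker inhibitor, a lower number a stronger inhibitor. Compound 1 `CC(=O)NC(=S)Nc1ccncc1` gives 2070 nM in this assay. Compound 2 `CC(=O)NC(=S)Nc1ccc(Br)cc1` gives 1640 nM, and compound 3 `CC(=O)NC(=S)Nc1ccc(Cl)cc1` gives 2210 nM. Compound 2 has the lowest of the three numbers, but its nearest neighbour is compound 1 and its furthest is compound 3, and both gaps sit within the scatter, so no ranking among the three is claimed.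

Among the measured compounds shown here, the one step that can be read directly is a 1.3-fold higher number from compound 2 to compound 3 (0.13 log units; within the scatter), a halogen exchange that does not move the number beyond the scatter.

The next compound, compound 4 `CC(=O)NC(=S)Nc1ccc(Br)c(C(F)(F)F)c1`, keeps the bromo group of compound 2 and differs by trifluoromethyl in place of hydrogen on an aromatic carbon. For the measured compounds named here, no measured step in this set adds a group to the aromatic ring while keeping the rest unchanged, so nothing in the data bears directly on this change. Going by the values given here, the only available step, from compound 2 to compound 3, is within the scatter, and it gives no direction to extrapolate from.

On that basis compound 4 is expected to stay near compound 2, with an estimated step of a 1.3-fold lower number from compound 2 to compound 4 (0.10 log units; within the scatter). The estimate for compound 4 in this assay is 1300 nM, with a range from 400 nM to 4000 nM.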

Compound 4, half-maximal inhibitory concentration: 1390 nM
Estimate against measurement, compound 4: 1.1-fold (0.03 log units) below, and the stated range covers the measured number.
By their numbers in this assay, from the lowest: compounds 4, 2, 1 and 3 (each within the scatter of the next).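

In this assay, among the compounds shown here, this is the first step that adds a group to the aromatic ring while the rest of the structure stays unchanged: a 1.2-fold lower number from compound 2 to compound 4 (0.07 log units; within the scatter). It shows that trifluoromethyl, with its 4 heavy atoms, can stand in place of hydrogen on this aromatic carbon, ortho to a bromo group and meta to a group of 7 heavy atoms, without taking the number beyond the scatter, something the earlier halogen exchange could not show for this position. No measurement to hand bears on this result or offers any account of it.

What the compounds shown leave open is whether this position would respond the same way to a different kind of group, such as an amine, a carboxylic acid or a longer alkyl chain, since trifluoromethyl is the only group seen there so far. On these data alone, it is also open whether trifluoromethyl at this position would give a similar result alongside chloro in place of bromo, or with no halogen on the ring at all.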